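The source may hold more compounds than are shown below. What is called first, only, known or untested is meant among the compounds shown, and "the series" means these compounds.

Measured in a functional assay on HeLa cells (Homo sapiens) for cytotoxicity, with a stated time of 72 h; on this read-out higher numbers stand for weaker inhibition and lower numbers for stronger inhibition:
- compound 1 `O=[N+]([O-])c1ccc(-c2nc3sc(Cc4ccc(Cl)cc4)nn3c2Br)cc1`: > 250000 nM, a limit of the assay rather than a number.
- compound 2 `O=Cc1c(-c2ccc(Br)cc2)nc2sc(Cc3ccc(Cl)cc3)nn12`: 4200 nM.
- compound 3 `N#CSc1c(-c2ccc(Br)cc2)nc2sc(Cc3ccc(Cl)cc3)nn12`: 22000 nM.

Compound 3 holds the highest of the two numbers shown; its nearest neighbour is compound 2, and the step of a 5.2-fold higher number from compound 2 to compound 3 (0.72 log units; beyond the scatter) lies beyond the scatter. Compound 4 `N#CSc1c(-c2ccc([N+](=O)[O-])cc2)nc2sc(Cc3ccc(Cl)cc3)nn12` differs from compound 3 in one place: nitro in place of bromo on an aromatic carbon. Among the compounds with values here, no measured step touches this position. Within the data shown here, the single measured step, a 5.2-fold higher number from compound 2 to compound 3 (0.72 log units; beyond the scatter), concerns the group on the shared core and not the phenyl ring, so it gives no guide to the size of the present change. Among the measured compounds shown here, the only compound carrying a nitrophenyl group is compound 1, which sits at the limit (the limit of > 250000 nM in this assay, at which 1 of the 3 values shown sits). For the measured compounds named here, compound 1 and compound 3 differ in two places, so no step between them is counted; their two values show only that the nitrophenyl compound returned a limit while compound 3 returned a number. A weakening is therefore expected, a 3.6-fold higher number from compound 3 to compound 4 (0.56 log units; beyond the scatter), with a fair chance that only a limit is reported. Compound 4 is expected at 80000 nM, within 20000 nM to 300000 nM.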

Compound 4, half-maximal inhibitory concentration: 16000 nM
Compound 4: the middle estimate sits 5.0-fold (0.70 log units) above what was measured; the whole stated range lies above it.
By their numbers in this assay, from the lowest: compound 2; then compounds 4 and 3 (each within the scatter of the next). At a limit, above all of these: compound 1.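

In this assay, 4-bromophenyl to 4-nitrophenyl gives a 1.4-fold lower number from compound 3 to compound 4 (0.14 log units; within the scatter), so with cyanosulfanyl on the shared core, this position accepts either group without a readable difference. The nitrophenyl group therefore does not by itself go with a limit, and with the nitrophenyl group held constant, cyanosulfanyl in place of bromo on the aromatic carbon of the shared core gives an at least 15-fold lower number from compound 1 to compound 4 (1.19 log units; beyond the scatter). Compound 1 stands at a limit and not at a number: the limit of > 250000 nM in this assay, at which 1 of the 4 values shown sits.

On these data alone, whether the same indifference to bromo or nitro holds with formyl on the shared core, as in compound 2, remains open. Within the data shown here, also open is how an amine or a carboxylic acid would read on this phenyl ring, since bromo and nitro are the only two groups compared here.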